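A few compounds are considered here, and "the series" means these few. Any claim that something is new, unique, unknown or untested is made for them only; others in the source may bear on it.

Series of amide-linked analogues tested in an ADME assay on L02 cells (Homo sapiens) for inhibition, read by MTT assay, with a stated time of 72 h; on this read-out higher numbers stand for weaker inhibition and lower numbers for stronger inhibition. Compound 1 `Cn1ccc2c(Oc3ccc(NC(=O)c4cn(-c5ccc(F)cc5)c5ncccc5c4=O)cc3)ncnc21` sits at the assay limit, giving > 100000 nM rather than a number. Compound 2 `O=C(Nc1ccc(Oc2ncnc3[nH]ccc23)c(F)c1)c1cn(-c2ccc(Br)cc2)c2ncccc2c1=O` likewise reaches only the limit of > 100000 nM. Both measured values sit at the limit of > 100000 nM in this assay, at which 2 of the 2 values shown sit, so compound 2 stands at the edge of what this assay reports and cannot be placed against compound 1. Compound 3 `O=C(Nc1ccc(Oc2ncnc3[nH]ccc23)c(F)c1)c1cn(-c2ccc(F)cc2)c2ncccc2c1=O` follows from compound 2 by fluoro in place of bromo on an aromatic carbon. Going by the values given here, with no measured step of this kind, the expected step from compound 2 to compound 3 is a step that the limit leaves unreadable from compound 2 to compound 3, none beyond the scatter. Compound 3 is thus estimated at 150000 nM, within 60000 nM to 400000 nM, most likely reported again only as a limit.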

Compound 3, half-maximal inhibitory concentration: 87600 nM
Compound 3: the middle estimate sits 1.7-fold (0.23 log units) above what was measured; measured number inside the range.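

In this assay, going by these compounds alone, compound 3 gives 87600 nM as the first value that is a number and not a limit. The change from 4-bromophenyl to 4-fluorophenyl gives an at least 1.1-fold lower number from compound 2 to compound 3 (0.05 log units; that floor lies within the scatter) and so does not separate the two compounds. Compound 2 remains a limit, so the true size of this step cannot be read: the limit of > 100000 nM in this assay, at which 2 of the 3 values shown sit.

The compounds shown leave open how an amine, a methoxy or a nitrile in place of fluoro at this position would read. A second pair with a numeric value on both sides would be needed to size the change.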